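Replacing phenyl with thiophen-3-yl in compound 3

This account rests on a few compounds, and the source may have more. Where it says the series, first, only, none or still open, it means among the compounds named here.

Measured in a functional assay on MCF7 cells (Homo sapiens) for cytotoxicity; a lower number here means a stronger inhibitor, a higher number a weaker inhibitor:
Compound 1 `C=C/C=C\[C@H](C)[C@H](OC(N)=O)[C@@H](C)[C@H](O)[C@@H](C)C/C(C)=C\[C@H](C)[C@@H](O)[C@@H](C)/C=C\CCc1ccc(C)c(F)c1`: 4000 nM
Compound 2 `C=C/C=C\[C@H](C)[C@H](OC(N)=O)[C@@H](C)[C@H](O)[C@@H](C)C/C(C)=C\[C@H](C)[C@@H](O)[C@@H](C)/C=C\CCc1ccc(C)c(O)c1`: 4000 nM
Compound 3 `C=C/C=C\[C@H](C)[C@H](OC(N)=O)[C@@H](C)[C@H](O)[C@@H](C)C/C(C)=C\[C@H](C)[C@@H](O)[C@@H](C)/C=C\CCc1ccccc1`: 560 nM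

Compound 3 stands lowest of the three at 560 nM, and its gap to each of the other two lies beyond the scatter. Compound 4 `C=C/C=C\[C@H](C)[C@H](OC(N)=O)[C@@H](C)[C@H](O)[C@@H](C)C/C(C)=C\[C@H](C)[C@@H](O)[C@@H](C)/C=C\CCc1ccsc1` has not yet been measured in this assay. It differs from compound 3 in one place: thiophen-3-yl in place of phenyl on a saturated chain carbon, two bonds along the chain from a double-bonded chain carbon The new group is thiophen-3-yl in place of phenyl on a saturated chain carbon, two bonds along the chain from a double-bonded chain carbon.

Among the measured compounds shown here, two measured steps touch this same place. They are a 7.1-fold lower number from compound 1 to compound 3 (0.85 log units; beyond the scatter) and a 7.1-fold lower number from compound 2 to compound 3 (0.85 log units; beyond the scatter), both modest, and in each a substituted phenyl gives way to plain phenyl. A third step, no change at the digits printed from compound 1 to compound 2 (within the scatter), shows no separation between the fluoro and hydroxy groups. None of these steps tests a ring other than phenyl, so the data give no direct measure of the swap to thiophen-3-yl. Like phenyl, that group carries no further substituent, so the expectation starts from compound 3 and its 560 nM.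

The expected outcome is a 1.1-fold higher number from compound 3 to compound 4 (0.03 log units; within the scatter), which would be no change beyond the scatter. For compound 4 the estimated value is 600 nM, with an expected range of 250 nM to 1500 nM.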

Compound 4, half-maximal inhibitory concentration: 4000 nM
For compound 4 the middle estimate is 6.7-fold (0.82 log units) below the measured one; measured number above the stated range.
By their numbers in this assay, from the lowest: compound 3; then compounds 1, 2 and 4 (each within the scatter of the next).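

In this assay, the swap of phenyl for thiophen-3-yl on this saturated chain carbon gave a 7.1-fold higher number from compound 3 to compound 4 (0.85 log units; beyond the scatter) and so showed that the lower number of compound 3 does not extend to every unsubstituted aromatic ring at this place. Until now, only substituted phenyl groups had been seen to raise the number here, but thiophen-3-yl carries no substituent and lands level with both of them, with no change at the digits printed from compound 2 to compound 4 (within the scatter) and no change at the digits printed from compound 1 to compound 4 (within the scatter) as the printed steps. Among these four compounds, plain phenyl alone stands apart, while the other three rings cannot be separated, and nothing available here accounts for that result.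

The compounds shown leave open whether the higher number belongs to thiophen-3-yl in particular or would also appear with other rings at this place, such as thiophen-2-yl, furan-3-yl or pyridin-3-yl. They also leave open which part of the substituted rings matters, since compound 1 and compound 2 each keep the methyl alongside a second group, and a 4-methylphenyl ring would separate the methyl from the fluoro and hydroxy groups.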